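The compounds below may be only part of what the source reports. "The series", "measured", "known", "first", "only" and "open" are said of these compounds alone.

Compound 1 `CCn1c(N)c(-c2nc3ccccc3[nH]2)c2nc(C#N)c(C#N)nc21` gives > 50000 nM in a functional assay on cells (Homo sapiens) for antiproliferative activity, read by MTT assay, with a stated time of 48 h (a higher number here means a weaker inhibitor, a lower number a stronger inhibitor), which is a limit of the assay and not a number. Compound 2 `N#Cc1nc2c(-c3nc4ccccc4[nH]3)c(N)n(CCN3CCCC3)c2nc1C#N` gives > 50000 nM, also a limit. For the measured compounds named here, compound 3 `CCN(CC)CCCn1c(N)c(-c2nc3ccccc3[nH]2)c2nc(C#N)c(C#N)nc21`, which carries a 3-(diethylamino)propyl group, gives 28900 nM, the only true number of the three.

Compound 4 `N#Cc1nc2c(-c3nc4ccccc4[nH]3)c(N)n(CCCO)c2nc1C#N` differs from compound 3 by hydroxy in place of diethylamino on a saturated chain carbon, three bonds along the chain from an aromatic nitrogen. This is hydroxy in place of diethylamino, on a saturated chain carbon, three bonds along the chain from an aromatic nitrogen, so 3-(diethylamino)propyl becomes 3-hydroxypropyl.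

Going by the values given here, no measured step makes this exact exchange, so the guidance is indirect. Compound 1 has no diethylamino group, and the measured change that adds it is an at least 1.7-fold lower number from compound 1 to compound 3 (0.23 log units; that floor lies within the scatter). The comparison with the pyrrolidin-1-yl group of compound 2 is an at least 1.7-fold lower number from compound 2 to compound 3 (0.23 log units; that floor lies within the scatter). Both steps are only floors, and a step that the two limits leave unreadable from compound 1 to compound 2 adds nothing readable.

Losing the diethylamino group is therefore expected to push the number up, probably towards the limit, by a modest amount that these floors cannot fix. The expected change is a 1.7-fold higher number from compound 3 to compound 4 (0.24 log units; within the scatter). For compound 4 the estimated value in this assay is 50000 nM, with an expected range from 20000 nM to 100000 nM, and a report of only a limit would be no surprise.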

Compound 4, half-maximal inhibitory concentration: > 50000 nM
Compound 4 was reported as a limit; the forecaster's own chance of this, stated with the estimate: 55%; the middle value lies on the limit itself.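

In this assay, putting hydroxy in place of diethylamino on a saturated chain carbon, three bonds along the chain from an aromatic nitrogen, gives an at least 1.7-fold higher number from compound 3 to compound 4 (0.23 log units; that floor lies within the scatter). For the compounds shown here, this exchange keeps the propyl chain and alters only the group at its end, so compound 4 adds a comparison the earlier compounds lacked: 3-(diethylamino)propyl against 3-hydroxypropyl, with the chain itself held the same. Compound 4 is reported only as a limit, so compound 3 remains the only one of the four with a true number, though the floor of this step stays within the scatter and the steps to compound 4 from compound 1 and compound 2 cannot be read, since each joins two limits: the limit of > 50000 nM in this assay, at which 3 of the 4 values shown sit.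

The compounds shown leave open whether other amines at the end of the propyl chain, such as dimethylamino or piperidin-1-yl, would give a number like that of compound 3, and whether a longer chain carrying diethylamino would shift it in either direction. They also leave open how a carboxylic acid in place of the hydroxy group would read in this assay.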